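The compounds below may be only part of what the source reports. "The series", "measured", "known", "first", "only" and "open" are said of these compounds alone.

Measured in a functional assay on WI-38 VA13 cells (Homo sapiens) for cytotoxicity; on this read-out lower numbers stand for an effect already at smaller amounts and higher numbers for an effect only at larger amounts of compound:
- compound 1 `Cn1ncc([N+](=O)[O-])c1C(=O)Nc1ccc2nc(NC(=O)C3CCCCC3)sc2c1`: 0.026 ug/mL
- compound 2 `Cc1[nH][n+](C)c(C)c1C(=O)Nc1ccc2nc(NC(=O)C3CCCCC3)sc2c1`: 0.012 ug/mL
- compound 3 `CCCCCCCC(=O)Nc1nc2ccc(NC(=O)c3c(Cl)cccc3Cl)cc2s1`: 0.18 ug/mL

Compound 3 gives the highest number of the three in this assay. Among the compounds with values here, the only measured step, a 2.2-fold lower number from compound 1 to compound 2 (0.34 log units; beyond the scatter), concerns the other amide of the shared core and does not touch the carbonyl carbon changed here, so no measured step bears on the move to compound 4 `CCNC(=O)Nc1nc2ccc(NC(=O)c3c(Cl)cccc3Cl)cc2s1`.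

Change: ethylamino in place of heptyl on a carbonyl carbon

Within the data shown here, with no comparable step available, the direction of the effect cannot be read from the data; the expectation for compound 4 is therefore an estimate of a 2.8-fold higher number from compound 3 to compound 4 (0.44 log units; beyond the scatter) with a wide range. Compound 4 is expected at 0.5 ug/mL, somewhere between 0.1 ug/mL and 3 ug/mL.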

Compound 4, half-maximal effective concentration: 0.032 ug/mL
For compound 4 the middle estimate is 16-fold (1.19 log units) above the measured one; the measured number lies below the stated range.
By their numbers in this assay, from the lowest: compound 2; then compounds 1 and 4 (each within the scatter of the next); then compound 3.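

At this carbonyl carbon, the shared core tolerates ethylamino in place of heptyl: a 5.6-fold lower number from compound 3 to compound 4 (0.75 log units; beyond the scatter) in this assay. The long heptyl chain is therefore not required for a low number on this read-out, and the smaller group with its added hydrogen-bond donor gives the lower value. No measured property accounts for this step.

As far as these compounds go, the step changes chain length and introduces the nitrogen together, so their separate contributions remain open. A propyl group or a butylamino group on the same carbonyl carbon would begin to separate them.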